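The source may report more compounds than this note shows. Statements on the series, on what has been measured and on what is new or still open speak of the compounds shown alone.

In a functional assay on PC-3 cells (Homo sapiens) for inhibition, read by MTT assay, with a stated time of 48 h, tested at 10 uM (a lower number here means less inhibition of growth, a higher number more inhibition of growth at the concentration tested), compound 1 `Cc1cc(=O)c2c(O)cc(O)c([C@H]3CCN(C)C[C@H]3OC(=O)c3ccco3)c2o1` gives 23%, compound 2 `Cc1cc(=O)c2c(O)c(CN3CCCCC3)c(O)c([C@H]3CCN(C)C[C@H]3O)c2o1` gives 14%, and compound 3 `Cc1oc2c([C@H]3CCN(C)C[C@H]3O)c(O)cc(O)c2c(=O)c1C(O)c1ccc(F)c(Br)c1` gives 72%. Compound 3 therefore stands highest of the three, beyond the scatter from both of the others. Compound 4 `Cc1oc2c([C@H]3CCN(C)C[C@H]3O)c(O)cc(O)c2c(=O)c1C(O)c1ccc(F)cc1` differs from it in one place, with 3-bromo-4-fluorophenyl becoming 4-fluorophenyl: hydrogen in place of bromo on an aromatic carbon. This is hydrogen in place of bromo on an aromatic carbon. Among the measured compounds shown here, no measured pair shows this change alone, so the data give no direct guide to its size. A moderate fall in this assay is expected, with the estimate being a number 17 percentage points lower from compound 3 to compound 4 (beyond the scatter). For compound 4 the expected value is 55%, within an estimated range of 30% to 78%.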

Compound 4, percent growth inhibition at one concentration: 0%
For compound 4 the middle estimate is 55 percentage points above the measured one, and the stated range ends above it.
By their numbers in this assay, from the lowest: compound 4; then compounds 2 and 1 (each within the scatter of the next); then compound 3.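

Hydrogen in place of bromo on this aromatic carbon, ortho to the fluoro group, is a large change: in this assay the reading falls by a number 72 percentage points lower from compound 3 to compound 4 (beyond the scatter), and this pair shows that the growth inhibition of compound 3 depends on this one position. With compound 4 at 0%, the 4-fluorophenyl group alone retains none of that inhibition at the concentration tested. Nothing available explains this loss. Going by these compounds, it remains open whether chloro, methyl or methoxy at this position would retain the inhibition, and whether bromo would do so without the fluoro group.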